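A few compounds are considered here, and "the series" means these few. Any claim that something is new, unique, unknown or untested is made for them only; others in the source may bear on it.

Measured compounds:
compound 1 `Nc1ccccc1NC(=O)c1ccc(CNC2=N[C@@H](Cc3ccccc3)CS2)cc1` — 34900 nM
compound 2 `Nc1ccccc1NC(=O)c1ccc(CNC2=NC(=O)C(c3ccccc3)N2)cc1` — 8000 nM

In an assay for inhibition of histone deacetylase 8 (Homo sapiens), read by fluorescence, with stated times of 15 min and 60 min (on this read-out higher numbers stand for weaker inhibition and lower numbers for stronger inhibition), compound 2 gives 8000 nM, the lowest number of the two measured. Within the data shown here, compound 1 gives 34900 nM, a higher number that lies beyond the scatter; the two structures differ in more than one place, so the pair shows only that the core of compound 2 comes out with the lower number.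

Compound 3 `Nc1ccccc1NC(=O)c1ccc(CNC2=NC(=O)C(Cc3c[nH]c4ccccc34)N2)cc1` is built on the core of compound 2 and differs from it in one place: (1H-indol-3-yl)methyl in place of phenyl on a saturated ring carbon. Among the measured compounds shown here, no measured pair shows a change of this kind, so there is no step to lean on; the only anchor is compound 2 with 8000 nM in this assay.

The expected step of a 1.6-fold lower number from compound 2 to compound 3 (0.20 log units; within the scatter) is small, toward a lower number, and may well fall within the scatter. Compound 3 is expected to give 5000 nM in this assay, with a range from 1500 nM to 20000 nM.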

Compound 3, half-maximal inhibitory concentration: > 20000 nM
Compound 3: a limit, no number; the forecaster's own chance of this, stated with the estimate: 5%; middle value at least 4.0-fold (0.60 log units) from the limit.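

In this assay compound 3 gives > 20000 nM, which is a limit of the assay and not a number. (1H-indol-3-yl)methyl in place of phenyl on the saturated ring carbon gives an at least 2.5-fold higher number from compound 2 to compound 3 (0.39 log units; beyond the scatter). Among these compounds, this is the first change that can be read at a single place, and it shows that the read-out at this position depends on the group carried there, with this larger group on the side of the higher number. The step has a lower bound but no upper bound, so its full size stays unknown: the limit of > 20000 nM in this assay, at which 1 of the 3 values shown sits.

A single step at this position cannot separate the possible sources of the shift: the larger group as a whole, the methylene link that sets the ring system away from the saturated ring carbon, or the hydrogen-bond donor of the indole. The compounds shown also leave open how a benzyl group, a plain methyl group or a carboxylic acid on a short chain would read at this ring carbon, and so whether any group there gives a lower number than phenyl.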